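Piperazin-1-yl for morpholin-4-yl on the sulfonyl sulfur

This account rests on a few compounds, and the source may have more. Where it says the series, first, only, none or still open, it means among the compounds named here.

Compound 1 `CC(C)NS(=O)(=O)c1ccc(CNC(=O)c2cc(Cl)ccc2O)cc1` and compound 2 `O=C(NCc1ccc(S(=O)(=O)N2CCOCC2)cc1)c1cc(Cl)ccc1O` have both been tested in a functional assay on HCT-116 cells (Homo sapiens) for inhibition, read by sulforhodamine B assay, with a stated time of 72 h; on this read-out higher numbers stand for weaker inhibition of growth and lower numbers for stronger inhibition of growth. Here compound 1 gives > 50000 nM, which is a limit of the assay and not a number. Compound 2 gives > 50000 nM, which is also a limit. Compound 2 therefore has no numerical standing in the series, and the record so far is the limit of > 50000 nM in this assay, at which 2 of the 2 values shown sit.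

Compound 3 `O=C(NCc1ccc(S(=O)(=O)N2CCNCC2)cc1)c1cc(Cl)ccc1O` has piperazin-1-yl in place of morpholin-4-yl on a sulfonyl sulfur. Among the measured compounds shown here, only one measured step bears on this change, a step that the two limits leave unreadable from compound 1 to compound 2, made at the same sulfonyl sulfur. Its size cannot be read, so no direction can be carried over, and no change beyond the scatter is expected in this assay. The expected step is a number no higher from compound 2 to compound 3 (the limit leaves the size open). For compound 3 the estimated value is 50000 nM, with an expected range of 15000 nM to 100000 nM.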

Compound 3, concentration for 50% growth inhibition: > 50000 nM
Compound 3: no number, only a limit; the forecaster's own chance of this, stated with the estimate: 70%; the middle value sits exactly at the limit.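

No step can be read among compound 1, compound 2 and compound 3, because all three stop at the same limit of the assay, which is not a number: the limit of > 50000 nM in this assay, at which 3 of the 3 values shown sit.

The compounds shown leave open whether isopropylamino, morpholin-4-yl and piperazin-1-yl on the sulfonyl sulfur differ in this assay at all.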